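From dimethylsulfamoyl to sulfamoyl on the shared core

The compounds below may be only part of what the source reports. "The series", "measured", "known", "first", "only" and "open" are said of these compounds alone.

Within the data shown here, compound 2 `CN(C)S(=O)(=O)c1ccc2nc(-c3ccc(-c4ccccc4F)cc3)[nH]c2c1` carries the only number in an assay on isolated protein for inhibition of acyl-CoA desaturase 1 (Rattus norvegicus) (a higher number here means a weaker inhibitor, a lower number a stronger inhibitor), where compound 2 gives 528 nM. Compound 1 `N#Cc1ccc2nc(-c3ccc(-c4ccccc4F)cc3)[nH]c2c1` sits at a limit in this assay, giving > 20000 nM. Among the measured compounds shown here, the single measured step, an at least 37-fold lower number from compound 1 to compound 2 (1.57 log units; beyond the scatter), rests on (the limit of > 20000 nM in this assay, at which 1 of the 2 values shown sits). Compound 3 `NS(=O)(=O)c1ccc2nc(-c3ccc(-c4ccccc4F)cc3)[nH]c2c1` differs from compound 2 by amino in place of dimethylamino on a sulfonyl sulfur. That step concerns the whole sulfur substituent and not its amino part, so it gives no direction here; a modest change or none beyond the scatter is expected in this assay. Compound 3 is estimated at 800 nM, within 250 nM to 3000 nM, an expected step of a 1.5-fold higher number from compound 2 to compound 3 (0.18 log units; within the scatter).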

Compound 3, half-maximal inhibitory concentration: 343 nM
Beside the measured number, compound 3's estimate is 2.3-fold (0.37 log units) above it; the range from low to high includes it.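

With amino in place of dimethylamino on the sulfonyl sulfur, this assay shows a 1.5-fold lower number from compound 2 to compound 3 (0.19 log units; within the scatter), so this assay does not separate the two sulfur substituents and the dimethyl substitution is not required for activity at this level. The contrast with cyano on the aromatic carbon therefore holds for sulfamoyl as well, with an at least 58-fold lower number from compound 1 to compound 3 (1.76 log units; beyond the scatter). The size of that step stays a bound: the limit of > 20000 nM in this assay, at which 1 of the 3 values shown sits.

Going by these compounds, whether a single methylamino or a piperidine or morpholine ring on the sulfonyl sulfur keeps this level remains open. Also open, on these data alone, is whether a group without sulfur on the aromatic carbon, such as a carboxylic acid or an amide, can do the same.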